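Swapping the aryl group on the hydrazone of compound 3

The compounds below may be only part of what the source reports. "The series", "measured", "known", "first", "only" and "open" are said of these compounds alone.

Of the compounds shown here, three sharing one core have been tested in a functional assay on A549 cells (Homo sapiens) for antiproliferative activity, read by MTT assay; on this read-out lower numbers stand for stronger inhibition and higher numbers for weaker inhibition. Compound 1 `Cn1c(=O)c(=O)n(C2CCCC2)c2nc(N/N=C/c3ccc(Cl)cc3)ncc21` gives 6890 nM, compound 2 `Cn1c(=O)c(=O)n(C2CCCC2)c2nc(N/N=C/c3ccc(F)c(Cl)c3)ncc21` gives 9410 nM, and compound 3 `Cn1c(=O)c(=O)n(C2CCCC2)c2nc(N/N=C/c3ccccc3F)ncc21` gives 31200 nM. Compound 3 thus stands highest of the three, with compound 2 nearest and compound 1 furthest, as shown by a 3.3-fold higher number from compound 2 to compound 3 (0.52 log units; beyond the scatter) and a 4.5-fold higher number from compound 1 to compound 3 (0.66 log units; beyond the scatter). Between compound 1 and compound 2 the step was a 1.4-fold higher number from compound 1 to compound 2 (0.14 log units; within the scatter).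

Compound 4 `Cn1c(=O)c(=O)n(C2CCCC2)c2nc(N/N=C/c3cc([N+](=O)[O-])ccc3Cl)ncc21` differs from compound 3 in one place: 2-chloro-5-nitrophenyl in place of 2-fluorophenyl on a carbon with a double bond to nitrogen. Among the measured compounds shown here, no measured step exchanges a fluorine for a chlorine and a nitro group on that ring, so only the two steps ending at compound 3 bear on it, and both were modest, leading from a differently substituted phenyl to the phenyl of compound 3. A step of similar modest size back toward lower numbers is therefore expected for a 2.1-fold lower number from compound 3 to compound 4 (0.32 log units; beyond the scatter), with wide uncertainty. Compound 4 is estimated at 15000 nM, within a range from 4000 nM to 55000 nM.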

Compound 4, half-maximal inhibitory concentration: 8780 nM
The estimate for compound 4 lay 1.7-fold (0.23 log units) above the measured number; measured number inside the range.
By their numbers in this assay, from the lowest: compounds 1, 4 and 2 (each within the scatter of the next); then compound 3.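

In this assay, 2-chloro-5-nitrophenyl in place of 2-fluorophenyl on the carbon with a double bond to nitrogen brings the number back down (a 3.6-fold lower number from compound 3 to compound 4 (0.55 log units; beyond the scatter)). Compound 4 cannot be told apart from the other two compounds (a 1.1-fold lower number from compound 2 to compound 4 (0.03 log units; within the scatter); a 1.3-fold higher number from compound 1 to compound 4 (0.11 log units; within the scatter)), so three differently substituted rings sit at one level, and only compound 3 stands apart. Both 2-fluorophenyl and 2-chloro-5-nitrophenyl carry a halogen at the position their names give as 2, so a halogen there does not by itself set the higher number.

No available evidence explains why the number moves with this change. As far as these compounds go, it remains open whether the chlorine or the nitro group accounts for the step, and whether a ring bearing an amine or a carboxylic acid would stay at this level.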